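Swapping Trifluoromethyl for Ethyl on the Aromatic Ring

The compounds below may be only part of what the source reports. "The series", "measured", "known", "first", "only" and "open" are said of these compounds alone.

Measured compounds:
compound 1, `O=C(O)CCCSCCN1C(=O)OC[C@@H]1/C=C/[C@@H](O)Cc1cccc(C(F)(F)F)c1`, 2 nM
compound 2, `CCc1cccc(C[C@H](O)/C=C/[C@H]2CSC(=O)N2CCSCCCC(=O)O)c1`, 0.88 nM

Both compounds were tested in an assay on CHO cells for displacement of a labelled ligand from prostaglandin E2 receptor EP4 subtype (Mus musculus), read by scintillation counting, with a stated time of 60 min; on this read-out lower numbers stand for stronger inhibition and higher numbers for weaker inhibition. Compound 1 gives 2 nM, the higher of the two numbers on hand. Compound 2 gives 0.88 nM, and the gap between the two lies beyond the usual scatter of repeated measurements. Compound 3, `CCc1cccc(C[C@H](O)/C=C/[C@H]2COC(=O)N2CCSCCCC(=O)O)c1`, has not yet been measured. It differs from compound 1 in one place: ethyl in place of trifluoromethyl on an aromatic carbon. Compound 2 already carries the ethyl group and shows the lower number, but it also differs from compound 3 within the shared core, so no single-change comparison for this swap exists among the measured compounds. On that basis a modest step toward a lower number is expected, a 1.5-fold lower number from compound 1 to compound 3 (0.19 log units; within the scatter), one that may well stay within the scatter. For compound 3 the estimate is 1.3 nM, with a range from 0.5 nM to 3.5 nM.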

Compound 3, inhibition constant: 7.9 nM
For compound 3 the middle estimate is 6.1-fold (0.78 log units) below the measured one; measured number above the stated range.
By their numbers in this assay, from the lowest: compound 2; then compound 1; then compound 3.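

The swap of trifluoromethyl for ethyl on the aromatic ring can now be read on its own: in this assay it gives a 4.0-fold higher number from compound 1 to compound 3 (0.60 log units; beyond the scatter), so on this core the 3-(trifluoromethyl)phenyl group goes with the lower number. Ethyl alone therefore does not bring a low number at this position: compound 2 also carries ethyl and gives 0.88 nM, whereas compound 3 gives 7.9 nM, and these two differ only within the shared core. Nothing measured here accounts for this step.

The compounds shown leave open whether the same swap would run in the same direction on the core of compound 2. They also leave open how a methyl group, a chlorine atom or a methoxy group at this aromatic carbon would compare with ethyl and trifluoromethyl.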